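The source may report more compounds than this note shows. Statements on the series, on what has been measured and on what is new or still open speak of the compounds shown alone.

In a functional assay on QGY7701 cells (Homo sapiens) for cytotoxicity, read by MTT assay, with a stated time of 24 h (on this read-out higher numbers stand for weaker inhibition and lower numbers for stronger inhibition), compound 1 `C=CC1=C(C(=O)NCCC)C(c2ccc(OC)c(OC)c2)OC1` reaches only a limit, > 100000 nM. Compound 3 `C=CC1=C(C(=O)NCCC)C(c2ccc(OC)cc2)OC1` likewise stops at a limit in this assay, > 100000 nM. Compound 2 `C=CC1=C(C(=O)NCC(C)C)C(c2ccc(OC)cc2)OC1` also gives no more than a limit in this assay, > 100000 nM. All three values therefore sit at the limit of > 100000 nM in this assay, at which 3 of the 3 values shown sit, so the step that the two limits leave unreadable from compound 1 to compound 3 cannot be sized, and the same holds for a step that the two limits leave unreadable from compound 2 to compound 3. Compound 1 thus stands nowhere in particular among the numbers shown: it is simply one of three compounds that fail to show cytotoxicity within the range of this assay.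

The new compound 4 `C=CC1=C(C(=O)NC2CCCCC2)C(c2ccc(OC)c(OC)c2)OC1` differs from compound 1 in one place: cyclohexyl in place of propyl on an amide-type nitrogen. Going by the values given here, no measured step bears directly on this change, as a step that the two limits leave unreadable from compound 1 to compound 3 and a step that the two limits leave unreadable from compound 2 to compound 3 touch other parts of the molecule and neither can be read. With nothing in this small set rising above the limit, the step of a number no higher from compound 1 to compound 4 (the limit leaves the size open) is expected to stay unreadable, most likely ending at another limit. Compound 4 is accordingly estimated at 100000 nM, between 40000 nM and 300000 nM.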

Compound 4, half-maximal inhibitory concentration: 7490 nM
The estimate for compound 4 lay 13-fold (1.13 log units) above the measured number, outside the stated range (below it).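

In this assay, the amide nitrogen is the only place among those shown where a change yields a readable step: cyclohexyl in place of propyl gives an at least 13-fold lower number from compound 1 to compound 4 (1.12 log units; beyond the scatter). The steps at the aromatic methoxy and on the chain carbon cannot be read, so this is the sole measure of how a change affects the read-out in this set. Compound 4 is also the only compound here that gives a number instead of a limit: the limit of > 100000 nM in this assay, at which 3 of the 4 values shown sit.

The compounds shown leave open whether the lower number goes with the ring or with the larger carbon count, which an open hexyl chain or a cyclopentyl group on the same nitrogen would help to separate. From the compounds shown here alone, it also remains open whether cyclohexyl gives a measurable number on the core of compound 3.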